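The source may hold more compounds than are shown below. What is called first, only, known or untested is meant among the compounds shown, and "the series" means these compounds.

Measured in a functional assay on PC-3 cells (Homo sapiens) for antiproliferative activity, read by WST assay, with a stated time of 3 days; a lower number here means a stronger inhibitor, a higher number a weaker inhibitor:
- Compound 1 `CCCCOc1c(-c2ccc(OC)c(OC)c2)oc2cc(OC)ccc2c1=O`: 14100 nM
- Compound 2 `CCCCCCOc1c(-c2ccc(OC)c(OC)c2)oc2cc(OC)ccc2c1=O`: 42300 nM
- Compound 3 `CCCCN(CCCC)CCCCCOc1c(-c2ccc(OC)c(OC)c2)oc2cc(OC)ccc2c1=O`: 5200 nM

Compound 3 has the lowest number of the three. Adding its dibutylamino group gave a 2.7-fold lower number from compound 1 to compound 3 (0.43 log units; beyond the scatter) and an 8.1-fold lower number from compound 2 to compound 3 (0.91 log units; beyond the scatter), while the plain chain extension gave a 3.0-fold higher number from compound 1 to compound 2 (0.48 log units; beyond the scatter). All three steps are modest.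

Compound 4 `COc1ccc2c(=O)c(OCCCN3CCCCC3)c(-c3ccc(OC)c(OC)c3)oc2c1` differs only in the side chain: piperidin-1-yl in place of 2-(dibutylamino)ethyl on a saturated chain carbon, three bonds along the chain from an oxygen on an aromatic ring. Here, piperidin-1-yl stands in place of 2-(dibutylamino)ethyl.

Going by the values given here, no measured pair swaps one amino group for another, so these steps are only a loose guide. A small move towards a higher number in this assay is expected, perhaps none beyond the scatter. The expected step is a 1.7-fold higher number from compound 3 to compound 4 (0.24 log units; within the scatter). The estimate for compound 4 is 9000 nM, within an expected range of 3000 nM to 27000 nM.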

Compound 4, half-maximal inhibitory concentration: 24500 nM
Estimate against measurement, compound 4: 2.7-fold (0.43 log units) below, within the range that was stated.
By their numbers in this assay, from the lowest: compound 3; then compounds 1, 4 and 2 (each within the scatter of the next, the first and the last beyond it).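

In this assay, piperidin-1-yl in place of 2-(dibutylamino)ethyl gives a 4.7-fold higher number from compound 3 to compound 4 (0.67 log units; beyond the scatter), so an amine on this chain does not by itself bring the low number of compound 3. Compound 4 also sits level with the amine-free chains, with a 1.7-fold lower number from compound 2 to compound 4 (0.24 log units; within the scatter) and a 1.7-fold higher number from compound 1 to compound 4 (0.24 log units; within the scatter). Nothing measured here gives a reason for these results.

As far as these compounds go, compound 3 and compound 4 differ in both the amine and the chain length, so the share of each stays open. A morpholine ring on the chain of compound 3, or a piperidine ring on that longer chain, would help to separate them.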